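This account rests on a few compounds, and the source may have more. Where it says the series, first, only, none or still open, it means among the compounds named here.

Compound 1 `COc1ccccc1-c1cnc(NC(=O)c2ccc(F)cc2)n1C` in a toxicity assay on THP-1 cells (Homo sapiens) for inhibition (a higher number here means that more compound is tolerated, a lower number that less compound is tolerated), gives > 100000 nM, which is a limit of the assay rather than a number.
Compound 2 `COc1ccccc1-c1cnc(NC(=O)c2ncc[nH]2)n1C` gives > 50000 nM, again a limit.
Compound 3 `COc1ccc(-c2cnc(NC(=O)C3CCOCC3)n2C)cc1` gives > 100000 nM, also a limit.

Compound 3 therefore stands only at a limit, and the two other values shown are limits as well: the limit of > 100000 nM in this assay, at which 2 of the 3 values shown sit, and (the limit of > 50000 nM in this assay, at which 1 of the 3 values shown sits). Compound 4 `COc1ccc(-c2cnc(NC(=O)c3cccc(Cl)c3)n2C)cc1` differs from compound 3 in one place: 3-chlorophenyl in place of oxan-4-yl on a carbonyl carbon. For the measured compounds named here, the one measured step that likewise swaps the group on the carbonyl carbon is a step that the two limits leave unreadable from compound 1 to compound 2, and its size cannot be read from the two limits at its ends. Going by the values given here, no measured step tells how large the move from compound 3 to compound 4 should be, and nothing in the numbers points in either direction. The expectation is that compound 4 stays at or near the limit, so the expected step is a number no higher from compound 3 to compound 4 (the limit leaves the size open), a change not beyond the scatter. Compound 4 is estimated at 100000 nM, with a range from 30000 nM to 300000 nM.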

Compound 4, half-maximal cytotoxic concentration: > 28000 nM
Compound 4: only a limit was reported; the forecaster's own chance of this, stated with the estimate: 70%; the middle value does not contradict the limit.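

Compound 3 and compound 4 each give only a limit of the assay rather than a number, so the step between them cannot be read. The compounds shown leave open what concentration of any of them would prove toxic in this assay, and whether changing the group on the carbonyl carbon matters.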